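From a Methanesulfonamido Group to a Phenyltriazole

This account rests on a few compounds, and the source may have more. Where it says the series, first, only, none or still open, it means among the compounds named here.

Compound 1 `COc1ccc(-c2c(C)nc3c(N4CC[C@@H](NS(C)(=O)=O)C4)cc(C)nn23)cc1OC` was tested in an ADME assay on microsomes from liver (Mus musculus) for metabolic stability, read by LC-MS, with NADPH named in the record, with a stated time of 60 min, tested at 1 uM, in the absence of a further agent; a lower number here means that less of the compound is left, a higher number that more of the compound is left. In this assay compound 1 gives > 95%, which is a limit of the assay rather than a number. Compound 2 `COc1ccc(-c2c(C)nc3c(N4CC[C@@H](NS(=O)(=O)c5ccc(NC(C)=O)cc5)C4)cc(C)nn23)cc1OC` gives > 95% in this assay, also a limit. Compound 3 `COc1ccc(-c2c(C)nc3c(N4CC=CC4)cc(C)nn23)cc1OC` gives > 95% in this assay, again a limit. The step that the two limits leave unreadable from compound 1 to compound 2 and the step that the two limits leave unreadable from compound 1 to compound 3 therefore cannot be sized, since (the limit of > 95% in this assay, at which 3 of the 3 values shown sit). Compound 4 `COc1ccc(-c2c(C)nc3c(N4CC[C@@H](n5cc(-c6ccccc6)nn5)C4)cc(C)nn23)cc1OC` differs from compound 1 in one place: 4-phenyl-1H-1,2,3-triazol-1-yl in place of methanesulfonamido on a saturated ring carbon. Going by the values given here, no measured step bears on this change with a readable size, so no direction beyond the scatter can be drawn from the data. Compound 4 is expected to give 85% in this assay, between 55% and 95%, which means an expected step of a number at least 10 percentage points lower from compound 1 to compound 4 (that floor lies within the scatter).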

Compound 4, percent of the compound remaining: "unstable" (no number reported)
No number was reported for compound 4; the estimate stays without a comparison.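

In this assay, going by these compounds alone, compound 4 gives "unstable" (no number reported), a description without a number, so no step from compound 1 to compound 4 can be read. Going by these compounds, how large a difference 4-phenyl-1H-1,2,3-triazol-1-yl makes in place of methanesulfonamido remains open.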